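A few compounds are considered here, and "the series" means these few. Any claim that something is new, unique, unknown or untested is made for them only; others in the source may bear on it.

Measured so far:
- Compound 1 `CNC(=O)[C@@H]1C[C@H](N2CCc3c(ncnc3OCCC3CC3)C2)CN1C(=O)c1ccc(CN)c(OC)c1`: in an assay on isolated protein for inhibition of serine protease 1 (Homo sapiens), read by fluorescence (on this read-out lower numbers stand for stronger inhibition and higher numbers for weaker inhibition), compound 1 gives 6 nM.
- Compound 2 `COc1cc(C(=O)N2C[C@@H](n3cc(C4CC4)nn3)C[C@H]2C(=O)N[C@H]2CCCC[C@@H]2c2ccccc2)ccc1CN`: in this assay compound 2 gives 19 nM.

Of these two numbers, compound 1 holds the lower one, and compound 2 stands clearly higher, a gap wider than the usual scatter; the two compounds differ in several places at once, so nothing more can be drawn from that pair.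

Compound 3 `CNC(=O)[C@@H]1C[C@H](N2CCc3c(ncnc3OCCc3ccccc3)C2)CN1C(=O)c1ccc(CN)c(OC)c1` changes compound 1 in a single spot: phenyl in place of cyclopropyl on a saturated chain carbon, two bonds along the chain from an oxygen on an aromatic ring. No measured pair in this set isolates that kind of swap, so there is no shown step to lean on. The change is confined to the far end of a side chain, and a modest step, possibly within the scatter, seems the most reasonable expectation, leaning if anything toward a slightly higher number. Compound 3 is therefore expected at about 10 nM, within a range from 3 nM to 30 nM. The step this estimate implies is a 1.7-fold higher number from compound 1 to compound 3 (0.22 log units; within the scatter).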

Compound 3, half-maximal inhibitory concentration: 5 nM
Compound 3: middle estimate off by 2.0-fold (0.30 log units), on the high side; the measured number falls inside the stated range.
By their numbers in this assay, from the lowest: compounds 3 and 1 (each within the scatter of the next); then compound 2.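

Within this assay, putting phenyl in place of cyclopropyl gives a 1.2-fold lower number from compound 1 to compound 3 (0.08 log units; within the scatter), so the two compounds cannot be told apart. Within the data shown here, this is the first comparison here that changes only one place, and it shows that a position on a saturated chain carbon, two bonds along the chain from an oxygen on an aromatic ring, can carry a six-membered aromatic ring of 6 heavy atoms as well as a three-membered ring of 3 heavy atoms, with no visible loss in this read-out. Nothing available explains why the number holds.

A single pair gives no general rule for this position. From the compounds shown here alone, it remains open whether an amine or a carboxylic acid at the end of the chain, or a longer chain, would leave the number within the same range.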